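A few compounds are considered here, and "the series" means these few. Any claim that something is new, unique, unknown or untested is made for them only; others in the source may bear on it.

Compound 3 `Clc1ccc(-c2nn(-c3ccccc3)cc2-c2nc3ccccc3[nH]2)cc1` is the compound from which this account starts. In a functional assay on A549 cells (Homo sapiens) for antiproliferative activity, read by MTT assay, with a stated time of 48 h (on this read-out lower numbers stand for stronger inhibition and higher numbers for weaker inhibition), compound 3 gives 5960 nM, the second highest of the three numbers measured. Its nearest neighbour is compound 2 `c1ccc(-c2nn(-c3ccccc3)cc2-c2nc3ccccc3[nH]2)cc1`, which in this assay gives 2710 nM; the step of a 2.2-fold higher number from compound 2 to compound 3 (0.34 log units; beyond the scatter) is a modest one, beyond the scatter. Furthest away stands compound 1 `O=Cc1cn(-c2ccccc2)nc1-c1ccc(Cl)cc1`, which in this assay gives 29500 nM; the step of a 4.9-fold lower number from compound 1 to compound 3 (0.69 log units; beyond the scatter) is also modest but beyond the scatter.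

Compound 4 `Cc1ccc2[nH]c(-c3cn(-c4ccccc4)nc3-c3ccc(Cl)cc3)nc2c1` differs from compound 3 in one place: methyl in place of hydrogen on an aromatic carbon. Among the measured compounds shown here, no measured step swaps a hydrogen for a methyl, so the only guide is indirect. The step of a 2.2-fold higher number from compound 2 to compound 3 (0.34 log units; beyond the scatter) shows that a single small substituent on an aromatic carbon shifted the number only modestly, and the methyl in compound 4 is a change of similar scale, so the expected step of a 1.2-fold lower number from compound 3 to compound 4 (0.08 log units; within the scatter) is small, in either direction, and likely within the scatter. Compound 4 is therefore estimated at 5000 nM, with a range from 2200 nM to 12000 nM.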

Compound 4, half-maximal inhibitory concentration: 4640 nM
Compound 4: the middle estimate sits 1.1-fold (0.03 log units) above what was measured, within the range that was stated.
By their numbers in this assay, from the lowest: compounds 2, 4 and 3 (each within the scatter of the next, the first and the last beyond it); then compound 1.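

In this assay, methyl in place of hydrogen on an aromatic carbon of the fused system gives a 1.3-fold lower number from compound 3 to compound 4 (0.11 log units; within the scatter), so a single added carbon at this position leaves the number within the scatter. The earlier steps shown here concerned chloro in place of hydrogen and 1H-benzimidazol-2-yl in place of formyl, and neither showed what a substituent on this six-membered ring of carbon only would do. There is no measured evidence that bears on why this methyl is tolerated.

On these data alone, whether this position would accept a group other than methyl stays open, since a methoxy group, an amine, a carboxylic acid or a longer chain could give a quite different number. As far as these compounds go, it is also open whether the methyl would behave the same way on the core of compound 2, which lacks the chloro.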